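The source may hold more compounds than are shown below. What is called first, only, known or untested is meant among the compounds shown, and "the series" means these compounds.

Compound 1 `COC(=O)CC/C=C\CC[C@H]1C(=O)C[C@@H](O)[C@@H]1/C=C/C[C@@](C)(O)/C=C/C1=CCCC1` has the lowest number of the two measured compounds: in a functional assay on the whole organism with Canis familiaris (Canis lupus familiaris) as the target (on this read-out lower numbers stand for an effect already at smaller amounts and higher numbers for an effect only at larger amounts of compound), compound 1 gives 0.00002 mg/kg. Compound 2 `CCCCC(C)(O)C/C=C/[C@H]1[C@H](O)CC(=O)[C@@H]1CC/C=C\CCC(=O)OC` gives 0.000023 mg/kg in this assay, and a 1.2-fold higher number from compound 1 to compound 2 (0.06 log units; within the scatter) shows that removing the whole cyclopentenyl-bearing end of that side chain changed nothing beyond the scatter. Compound 3 `C/C=C/C=C/[C@](C)(O)C/C=C/[C@H]1[C@H](O)CC(=O)[C@@H]1CC/C=C\CCC(=O)OC` differs from compound 1 by prop-1-en-1-yl in place of cyclopent-1-en-1-yl on a double-bonded chain carbon bound to a double-bonded chain carbon, a smaller change at the same end. Among the measured compounds shown here, the only comparable step is that one, so no shift beyond the scatter is expected, and the step of a 1.5-fold higher number from compound 1 to compound 3 (0.18 log units; within the scatter) is an estimate of that. Compound 3 is therefore expected to give 0.00003 mg/kg in this assay, within 0.00001 mg/kg to 0.00009 mg/kg.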

Compound 3, dose for half-maximal effect: 0.00003 mg/kg
Estimate against measurement, compound 3: no gap at the digits printed; measured number inside the range.
By their numbers in this assay, from the lowest: compounds 1, 2 and 3 (each within the scatter of the next).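

Replacing cyclopent-1-en-1-yl with prop-1-en-1-yl gives a 1.5-fold higher number from compound 1 to compound 3 (0.18 log units; within the scatter) in this assay and shows that this ring is not required for an effect at these very small doses. Replacing the saturated 1-hydroxy-1-methylpentyl with 1-hydroxy-1-methylhexa-2,4-dien-1-yl gives a 1.3-fold higher number from compound 2 to compound 3 (0.12 log units; within the scatter) and shows that this end of the chain can be saturated or carry two double bonds. No evidence is available to explain this tolerance. Still open, going by these compounds, is whether a group of a different kind at this place, such as an amine or a carboxylic acid, would keep the effect.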